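Cytotoxicity notes: hydrogen for chloro, compound 1 to compound 4

The source may report more compounds than this note shows. Statements on the series, on what has been measured and on what is new or still open speak of the compounds shown alone.

Measured in a functional assay on SH-SY5Y cells (Homo sapiens) for cytotoxicity, read by MTT assay, with a stated time of 48 h; on this read-out lower numbers stand for stronger inhibition and higher numbers for weaker inhibition:
compound 1 `FC(F)=C(F)CCSc1ncc(Cl)s1`: > 120000 nM.
compound 2 `O=S(=O)(CCC(F)(Cl)C(F)(F)Cl)c1nc2ccccc2s1`: 4500 nM.
compound 3 `[O-][S+](CCC(F)=C(F)F)c1nc2ccccc2o1`: 400 nM.

Compound 1 has as its result only a limit of the assay (the limit of > 120000 nM in this assay, at which 1 of the 3 values shown sits), so its place relative to the other two is not fixed by a number. Among the measured compounds shown here, compound 2 gives a measured number, and compound 3 gives a lower one; no single-point step connects them, so only the two values stand.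

Compound 4 `FC(F)=C(F)CCSc1nccs1` differs from compound 1 in one place: hydrogen in place of chloro on an aromatic carbon. For the measured compounds named here, no measured pair in this set carries a change of this kind. The step that the limit leaves unreadable from compound 1 to compound 4 is expected to be none beyond the scatter. Compound 4 is expected near 150000 nM, within 30000 nM to 700000 nM, and most likely reported again as a limit only.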

Compound 4, half-maximal inhibitory concentration: > 120000 nM
Compound 4 gave a limit, no number; the forecaster's own chance of this, stated with the estimate: 70%; the middle value lies beyond the limit too.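

No step can be read from compound 1 to compound 4, because both results are limits and not numbers: the limit of > 120000 nM in this assay, at which 2 of the 4 values shown sit.

Whether hydrogen in place of chloro on an aromatic carbon shifts cytotoxicity at all stays open in the compounds shown.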